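From thiophen-3-yl to thiophen-2-yl in compound 2

A few compounds are considered here, and "the series" means these few. Any claim that something is new, unique, unknown or untested is made for them only; others in the source may bear on it.

Compound 1 `COC(=O)C1=C(C)NC(C)=C(C(=O)OC)C1c1c(-c2ccccn2)nc2sccn12` gives 24400 nM
Compound 2 `COC(=O)C1=C(C)NC(C)=C(C(=O)OC)C1c1c(-c2ccsc2)nc2sc(C)cn12` gives 2300 nM
Compound 3 `COC(=O)C1=C(C)NC(C)=C(C(=O)OC)C1c1c(-c2ccsc2)nc2sccn12` gives 1060 nM

In a functional assay on cardiac atrium (Cavia porcellus) (a lower number here means that less compound is needed, a higher number that more compound is needed for the effect), compound 2 has the second highest number of the three at 2300 nM and compound 1 stands well above it. Its closest measured neighbour appears in a 2.2-fold lower number from compound 2 to compound 3 (0.34 log units; beyond the scatter) and that step is modest. Compound 4 `COC(=O)C1=C(C)NC(C)=C(C(=O)OC)C1c1c(-c2cccs2)nc2sc(C)cn12` has the same atoms as compound 2 joined differently, with thiophen-2-yl in place of thiophen-3-yl on an aromatic carbon and the methyl kept.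

For the measured compounds named here, no measured pair makes this exact exchange. The nearest evidence is a 23-fold lower number from compound 1 to compound 3 (1.36 log units; beyond the scatter) at the same carbon, a large step, but it replaced pyridin-2-yl and did not exchange thiophen-3-yl for thiophen-2-yl. The modest methyl step does not touch this carbon. A change no larger than the scatter is therefore expected, with either direction open, and the estimated step is a 1.2-fold lower number from compound 2 to compound 4 (0.06 log units; within the scatter) in this assay for this pair. For compound 4 the estimated value is 2000 nM with an expected range from 700 nM to 6500 nM on this read-out.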

Compound 4, half-maximal effective concentration: 40500 nM
Beside the measured number, compound 4's estimate is 20-fold (1.31 log units) below it, outside the stated range (above it).
By their numbers in this assay, from the lowest: compound 3; then compound 2; then compounds 1 and 4 (each within the scatter of the next).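

In this assay, the aromatic carbon next to the ring nitrogen proves sensitive to how the thiophene is attached, not only to which ring sits there: an 18-fold higher number from compound 2 to compound 4 (1.25 log units; beyond the scatter), although thiophen-3-yl and thiophen-2-yl have the same atoms, joined differently. The earlier large step at this carbon, a 23-fold lower number from compound 1 to compound 3 (1.36 log units; beyond the scatter), exchanged pyridin-2-yl for thiophen-3-yl, so it could not show that an exchange between two thiophen-yl groups can also produce a large step. No measurement at hand accounts for this difference between the two thiophen-yl groups.

The compounds shown leave open whether thiophen-2-yl has the same effect when hydrogen replaces the methyl, as in compound 3. They also leave open how a phenyl ring or a carboxylic acid on this carbon would compare with thiophen-3-yl.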